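The compounds below may be only part of what the source reports. "The series", "measured", "known", "first", "only" and "open" are said of these compounds alone.

Series notes, sulfonyl and benzyl variants of the shared core. In an ADME assay on MT4 cells (Homo sapiens) for cytotoxicity (a lower number here means that less compound is tolerated, a higher number that more compound is tolerated), compound 3 `Cc1cc(C)cc(S(=O)(=O)n2c(SCC(=O)Nc3ccc(S(N)(=O)=O)cc3Cl)nc3ccccc32)c1` gives 25600 nM. Compound 1 `Cc1cc(C)cc(S(=O)(=O)n2c(SCC(=O)Nc3ccc(S(C)(=O)=O)cc3Cl)nc3ccc(Cl)cc32)c1` gives 3590 nM, a lower number by a margin beyond the scatter. Compound 3 therefore holds the higher of the two exact numbers available. Compound 2 `Cc1cc(C)cc(Cn2c(SCC(=O)Nc3ccc(S(N)(=O)=O)cc3Cl)nc3ccc(Cl)cc32)c1` reads >= 18500 nM, and this is a limit of the assay rather than a number, so it cannot be ranked exactly against the others.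

The next compound to be tested is compound 4 `Cc1cc(C)cc(S(=O)(=O)n2c(SCC(=O)Nc3ccc(S(N)(=O)=O)cc3Cl)nc3ccc(Cl)cc32)c1`. It differs from compound 3 by chloro in place of hydrogen on an aromatic carbon. Going by the values given here, no measured pair in this set isolates that change, so the expectation rests on limited ground. Compound 1 also carries a chloro on the core and gives 3590 nM, which leans the expectation towards less compound being tolerated in this assay. Compound 1 also differs from compound 4 elsewhere, so only part of its gap from compound 3 is expected to carry over. The expected change is a 1.8-fold lower number from compound 3 to compound 4 (0.26 log units; within the scatter), a small move to a lower number that is not clearly beyond the scatter. For compound 4 the estimate is 14000 nM, with an expected range from 5000 nM to 32000 nM.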

Compound 4, half-maximal cytotoxic concentration: 23400 nM
For compound 4 the middle estimate is 1.7-fold (0.22 log units) below the measured one; measured number inside the range.
By their numbers in this assay, from the lowest: compound 1; then compounds 4 and 3 (each within the scatter of the next).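

In this assay, going by these compounds alone, this is the first pair that isolates chloro in place of hydrogen on an aromatic carbon of the shared core, and a 1.1-fold lower number from compound 3 to compound 4 (0.04 log units; within the scatter) places the change within the scatter. Chloro is present at both ends of the next step, where amino in place of methyl on a sulfonyl sulfur gives a 6.5-fold higher number from compound 1 to compound 4 (0.81 log units; beyond the scatter), so this gap goes with the change on the sulfur and not with the chloro. The step involving compound 2 cannot be read, as its value is a limit and not a number: the limit of >= 18500 nM in this assay, at which 1 of the 4 values shown sits.

On these data alone, on this aromatic carbon, only hydrogen and chloro are compared, so it remains open whether a methoxy group, an amine or a carboxylic acid there would also stay within the scatter of compound 3. As far as these compounds go, on the sulfonyl sulfur, only amino and methyl are compared, so the reading of a dimethylamino group or an ethyl chain remains open, as does the exchange of the (3,5-dimethylphenyl)sulfonyl and 3,5-dimethylbenzyl groups.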